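Series notes: aryl swap on the benzyl arm of compound 1

The source may hold more compounds than are shown below. What is called first, only, known or untested is meant among the compounds shown, and "the series" means these compounds.

Measured compounds:
compound 1 `OC[C@H]1O[C@@H](n2cnc3c(NCc4cccc(Br)c4)ncnc32)[C@H](O)[C@@H]1O` — 8000 nM
compound 2 `OC[C@H]1O[C@@H](n2cnc3c(NCc4ccc(Cl)c(Cl)c4)ncnc32)[C@H](O)[C@@H]1O` — 2000 nM
compound 3 `OC[C@H]1O[C@@H](n2cnc3c(NCc4ccc(F)cc4Cl)ncnc32)[C@H](O)[C@@H]1O` — 9000 nM

All three were read in a functional assay on HL-60 cells (Homo sapiens) for antiproliferative activity, with a stated time of 72 h; on this read-out higher numbers stand for weaker inhibition and lower numbers for stronger inhibition. Compound 1 sits second highest of the three numbers; against compound 3 the gap is a 1.1-fold higher number from compound 1 to compound 3 (0.05 log units; within the scatter), against compound 2 it is a 4.0-fold lower number from compound 1 to compound 2 (0.60 log units; beyond the scatter). The change from compound 2 to compound 3 runs a 4.5-fold higher number from compound 2 to compound 3 (0.65 log units; beyond the scatter). Within the data shown here, the only group that moves anywhere in this set is the aryl on the saturated chain carbon bound to a nitrogen on an aromatic ring; the shared core is untouched.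

Compound 4 `Cc1cccc(CNc2ncnc3c2ncn3[C@@H]2O[C@H](CO)[C@@H](O)[C@H]2O)c1O` is not yet measured. Its difference from compound 1 is 2-hydroxy-3-methylphenyl in place of 3-bromophenyl on a saturated chain carbon bound to a nitrogen on an aromatic ring. Among the measured compounds shown here, no measured step carries a hydroxyl or a methyl into this ring; every step so far exchanges one halogen pattern for another, and those steps stayed modest, with the largest being a 4.0-fold lower number from compound 1 to compound 2 (0.60 log units; beyond the scatter). For the measured compounds named here, the new aryl therefore has no close precedent here, and the expectation can only be anchored on compound 1 with wide bounds. Compound 4 is expected to give 12000 nM in this assay, within 3000 nM to 40000 nM. The estimated step is a 1.5-fold higher number from compound 1 to compound 4 (0.18 log units; within the scatter), a change not expected to clear the scatter with confidence in either direction.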

Compound 4, half-maximal inhibitory concentration: 15000 nM
Compound 4: the middle estimate sits 1.3-fold (0.10 log units) below what was measured, within the range that was stated.
By their numbers in this assay, from the lowest: compound 2; then compounds 1, 3 and 4 (each within the scatter of the next).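

Working notes on the benzyl arm: in this assay, 2-hydroxy-3-methylphenyl is the only aryl in the set without a halogen, yet it gives a 1.9-fold higher number from compound 1 to compound 4 (0.27 log units; within the scatter) and a 1.7-fold higher number from compound 3 to compound 4 (0.22 log units; within the scatter), so replacing the halogens with a hydroxyl and a methyl does not take the number outside the scatter of 3-bromophenyl or 2-chloro-4-fluorophenyl. The 3,4-dichlorophenyl of compound 2 now stands apart from all three other aryls, the widest gap being a 7.5-fold higher number from compound 2 to compound 4 (0.88 log units; beyond the scatter), so a halogen alone does not set the lower number, and compounds 1 and 3 are the halogen-bearing cases that go against such a link. No measurement at hand bears on what lies behind these differences.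

The hydroxyl and the methyl enter together, so their separate contributions cannot be read, and 2-hydroxyphenyl or 3-methylphenyl alone would be needed to divide them. Going by these compounds, it also remains open whether an amine or a carboxylic acid on this ring, or a longer chain in place of the benzyl arm, would take the number below that of compound 2 at 2000 nM.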